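Trimming the Chain on Compound 1

This account rests on a few compounds, and the source may have more. Where it says the series, first, only, none or still open, it means among the compounds named here.

Compound 1 `CC(C)Cn1cc(-c2ccnc3[nH]c(C4CCN(CC(=O)N(C)C)CC4)cc23)ccc1=O` was examined in an ADME assay on microsomes from liver (Homo sapiens) for metabolic stability (a lower number here means slower removal, a higher number faster removal of the compound), where compound 1 gives 21 uL/min. Among the three measured compounds this places compound 1 second highest. Compound 2 `COc1cc(F)ccc1-c1ccnc2[nH]c(C3CCOCC3)cc12` gives 10 uL/min, a lower number that lies beyond the scatter. Compound 3 `CC(C)n1cc(-c2ccnc3[nH]c(C4CCN(CC(=O)N5CCCC5)CC4)cc23)ccc1=O` gives 45 uL/min, a higher number that also lies beyond the scatter. Compound 4 `CCn1cc(-c2ccnc3[nH]c(C4CCN(CC(=O)N(C)C)CC4)cc23)ccc1=O` has not yet been measured in this assay. It differs from compound 1 in one place: methyl in place of isopropyl on a saturated chain carbon bound to an aromatic nitrogen. Going by the values given here, no measured pair shows this same change, so the size of the step remains open. A modest downward step is expected, a 1.5-fold lower number from compound 1 to compound 4 (0.18 log units; within the scatter), and it may well stay within the usual scatter. Compound 4 is estimated at 14 uL/min, with a range from 7 uL/min to 28 uL/min.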

Compound 4, intrinsic clearance in a liver preparation (reported as CLH), per the amount of preparation that the assay uses: < 3 uL/min
Compound 4 ended at the assay's limit; the forecaster's own chance of this, stated with the estimate: 5%; middle value at least 4.6-fold (0.66 log units) away from the limit.
By their numbers in this assay, from the lowest: compound 2; then compound 1; then compound 3. At a limit, below all of these: compound 4.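

In this assay, methyl in place of isopropyl on a saturated chain carbon bound to an aromatic nitrogen gives an at least 7.0-fold lower number from compound 1 to compound 4 (0.84 log units; beyond the scatter), so this one place can move the number beyond the scatter. The earlier compounds shown here included no pair differing in one place and could not show this. The reading for compound 4 is a limit of the assay, not a number: the limit of < 3 uL/min in this assay, at which 1 of the 4 values shown sits.

Going by these compounds, the full size of the step therefore stays open. The compounds shown also leave open how a cyclopropyl group or a methoxyethyl chain would read in this place.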